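The source may hold more compounds than are shown below. What is called first, only, known or untested is meant among the compounds shown, and "the series" means these compounds.

The study covers a small set built on a shared core with a butoxy-bearing aryl group and an acid side chain: compound 1 is `CCCCOc1cccc(C(=O)n2c(C)c(CC(=O)O)c3cc(OC)ccc32)c1`, compound 2 is `CCCCOc1ccc(C(=O)n2c(C)c(CC(=O)O)c3cc(OC)ccc32)cc1`, and compound 3 is `CCCCOc1ccc(C(=O)n2c(CCC)c(C(=O)O)c3cc(OC)ccc32)cc1`. In an assay on isolated protein for binding affinity to prostaglandin E2 receptor EP3 subtype (Mus musculus) (on this read-out higher numbers stand for weaker inhibition and lower numbers for stronger inhibition), compound 1 gives only a limit of the assay, > 10000 nM. In this assay compound 2 likewise returns only a limit, > 10000 nM. Compound 3 too gives only a limit in this assay, > 10000 nM. For the measured compounds named here, compound 2 therefore stands nowhere distinct: every value so far is the limit of > 10000 nM in this assay, at which 3 of the 3 values shown sit, so no measured step exists and no order among compounds 1, 2 and 3 can be read. Compound 4, `CCCCOc1ccc(C(=O)n2c(C)c(CCCCC(=O)O)c3cc(OC)ccc32)cc1`, differs from compound 2 by 3-carboxypropyl in place of carboxy on a saturated chain carbon bound to an aromatic carbon. Going by the values given here, with no measured step to lean on, the step implied by the estimate, an at least 1.2-fold lower number from compound 2 to compound 4 (0.09 log units; that floor lies within the scatter), is expected to be none beyond the scatter, though a move into the measurable range cannot be excluded. Compound 4 is estimated in this assay at 8000 nM, within a range from 1500 nM to 30000 nM, and a limit rather than a number is expected more often than not.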

Compound 4, inhibition constant: > 10000 nM
Compound 4 gave a limit, no number; the forecaster's own chance of this, stated with the estimate: 70%; at least 1.2-fold (0.09 log units) between middle value and limit.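

No step can be read from compound 2 to compound 4, since both compounds give only a limit and no number: the limit of > 10000 nM in this assay, at which 4 of the 4 values shown sit. In this assay the compounds shown leave open which change to the shared core, if any, would give a measured number rather than a limit.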